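This account rests on a few compounds, and the source may have more. Where it says the series, first, only, none or still open, it means among the compounds named here.

In a toxicity assay on HT-29 cells (Homo sapiens) for cytotoxicity (on this read-out lower numbers stand for higher toxicity in this test and higher numbers for lower toxicity in this test), compound 3 `CN1C(=S)[C@@H](NC(=O)c2nc(Cc3ccccc3)n(CCCO)n2)COc2ccccc21` gives > 100000 nM, which is a limit of the assay rather than a number. Compound 1 `CN1C(=S)[C@@H](NC(=O)c2n[nH]c(Cc3ccccc3)n2)COc2ccccc21` gives > 50000 nM, also a limit. Compound 2 `CN1C(=S)[C@@H](NC(=O)c2nc(Cc3ccccc3)n(C)n2)COc2ccccc21` gives > 100000 nM, again a limit. All three compounds thus stand at limits, so the steps between them, a step that the two limits leave unreadable from compound 1 to compound 2, a step that the two limits leave unreadable from compound 1 to compound 3 and a step that the two limits leave unreadable from compound 2 to compound 3, cannot be read in size. Compound 4 `CN1C(=S)[C@@H](NC(=O)c2nc(Cc3ccccc3)n(CC3COC3)n2)COc2ccccc21` differs from compound 3 by oxetan-3-yl in place of 2-hydroxyethyl on a saturated chain carbon bound to an aromatic nitrogen. The step that the two limits leave unreadable from compound 2 to compound 3 bears most directly on this change, yet its size is not readable, so no step beyond the scatter can be expected in either direction. Compound 4 is expected to give 100000 nM, in the range 50000 nM to 300000 nM, most likely again as a limit. This means an expected step of a number no higher from compound 3 to compound 4 (the limit leaves the size open).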

Compound 4, half-maximal cytotoxic concentration: > 100000 nM
Compound 4 was reported as a limit; the forecaster's own chance of this, stated with the estimate: 85%; the middle value sits exactly at the limit.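

Among these compounds, compound 4 gives only a limit, like compound 1, compound 2 and compound 3, and no step to compound 4 can be read. What stays open is the concentration at which any of these compounds becomes toxic to the cells.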